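The source may hold more compounds than are shown below. What is called first, only, known or untested is meant among the compounds shown, and "the series" means these compounds.

In a functional assay on HCT-116 cells (Homo sapiens) for inhibition, read by colorimetric assay, with a stated time of 3 days (a lower number here means a stronger inhibitor, a higher number a weaker inhibitor), compound 1 `O=C(CCCCCCNC(=O)c1cc(=O)c(O)co1)Nc1ccccc1` gives > 100000 nM, a limit and not a number. Compound 2 `O=C(CCCCCCNC(=O)C(O)(O)C(F)(F)F)Nc1ccc(Br)cc1` returns a true number, 3130 nM. Compound 3 `CC(=O)C(=O)NCCCCC(=O)Nc1ccccc1` gives > 100000 nM, also a limit and not a number; it stands at the limit of > 100000 nM in this assay, at which 2 of the 3 values shown sit. Compound 4 `NC(=O)C(=O)NCCCCC(=O)Nc1ccccc1` differs from compound 3 by amino in place of methyl on a carbonyl carbon, which reads as acetyl to carbamoyl: amino in place of methyl on a carbonyl carbon. Within the data shown here, no measured pair covers this change. In this assay the expected step, a number no higher from compound 3 to compound 4 (the limit leaves the size open), is therefore no larger than the scatter, with no direction favoured. Compound 4 is expected at 100000 nM, with an estimated range of 40000 nM to 200000 nM.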

Compound 4, half-maximal inhibitory concentration: > 100000 nM
Compound 4: a limit, no number (the forecaster's own chance of this, stated with the estimate: 75%); the middle value lies on the limit itself.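

No step can be read between compound 3 and compound 4: both give limits, not numbers. The compounds shown leave open whether amino in place of methyl on a carbonyl carbon alters inhibition at all.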